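The compounds below may be only part of what the source reports. "The series", "measured", "known", "first", "only" and "open" are said of these compounds alone.

Among the compounds with values here, compound 2, `Cc1ccc(S(=O)(=O)/N=C(/CCNC2=CC(=O)c3ccccc3C2=O)Nc2ccc(Cl)cc2Cl)cc1`, gives 41900 nM in an ADME assay on HEK293 cells (Homo sapiens) for cytotoxicity, read by MTT assay, with a stated time of 48 h (a higher number here means a weaker inhibitor, a lower number a stronger inhibitor), the lowest of the two numbers known there; compound 1, `Cc1ccc(S(=O)(=O)/N=C(/CCNC2=CC(=O)c3ccccc3C2=O)Nc2cccc(C(F)(F)F)c2)cc1`, gives 91500 nM. Within the data shown here, the only step known so far on this nitrogen is a 2.2-fold lower number from compound 1 to compound 2 (0.34 log units; beyond the scatter). Compound 3, `COc1cc(N/C(CCNC2=CC(=O)c3ccccc3C2=O)=N\S(=O)(=O)c2ccc(C)cc2)cc(OC)c1OC`, carries the change (3,4,5-trimethoxyphenyl in place of 2,4-dichlorophenyl on an amine nitrogen). Among the measured compounds shown here, no step involving a trimethoxyphenyl group is known, so that one modest step is the sole guide, and a step of similar size or none beyond the scatter is expected for compound 3 in this assay. Compound 3 is therefore expected to lie near 60000 nM, between 25000 nM and 150000 nM, a step of a 1.4-fold higher number from compound 2 to compound 3 (0.16 log units; within the scatter).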

Compound 3, half-maximal inhibitory concentration: 75800 nM
Beside the measured number, compound 3's estimate is 1.3-fold (0.10 log units) below it; the measured number falls inside the stated range.
By their numbers in this assay, from the lowest: compounds 2, 3 and 1 (each within the scatter of the next, the first and the last beyond it).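

In this assay, the 3,4,5-trimethoxyphenyl group on this amine nitrogen gives a 1.8-fold higher number from compound 2 to compound 3 (0.26 log units; within the scatter) and a 1.2-fold lower number from compound 1 to compound 3 (0.08 log units; within the scatter) and so cannot be told apart from either earlier group. This position therefore accepts a group of 12 heavy atoms with 3 hydrogen-bond acceptors without a step beyond the scatter, although compound 1 and compound 2 themselves stand apart. As far as these compounds go, whether an amine or a carboxylic acid on the aromatic ring, or a longer chain in its place, would shift the number stays open. No evidence at hand bears on why these numbers fall as they do.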